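Aryl swap on the sulfonamide nitrogen at the assay limit

A few compounds are considered here, and "the series" means these few. Any claim that something is new, unique, unknown or untested is made for them only; others in the source may bear on it.

Compound 1 `Cc1ccc(N(C)S(=O)(=O)C2CC3OC2C(c2ccc(NC(=O)CCCCCCC(=O)O)cc2)=C3c2ccc(O)cc2)cc1` gives > 100000 nM in an ADME assay on Vero cells (Chlorocebus sabaeus) for antiproliferative activity, read by MTT assay, with a stated time of 72 h (on this read-out higher numbers stand for weaker inhibition and lower numbers for stronger inhibition), which is a limit of the assay and not a number. Compound 2 `CCN(c1cccc(C)c1)S(=O)(=O)C1CC2OC1C(c1ccc(NC(=O)CCCCCCC(=O)O)cc1)=C2c1ccc(O)cc1` gives > 100000 nM in this assay, which is likewise a limit and not a number. Going by the values given here, the series so far therefore stands as follows: the limit of > 100000 nM in this assay, at which 2 of the 2 values shown sit.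

Compound 3 `CCN(c1ccccc1Br)S(=O)(=O)C1CC2OC1C(c1ccc(NC(=O)CCCCCCC(=O)O)cc1)=C2c1ccc(O)cc1` carries 2-bromophenyl in place of 3-methylphenyl on a sulfonamide nitrogen, the change from compound 2 being (2-bromophenyl in place of 3-methylphenyl on a sulfonamide nitrogen). Among the compounds with values here, the only measured step, a step that the two limits leave unreadable from compound 1 to compound 2, gives no size to carry forward, so for compound 3 no shift beyond the scatter is expected in this assay, and another limit is the likeliest report. The estimated step is a number no higher from compound 2 to compound 3 (the limit leaves the size open). Compound 3 is estimated at 100000 nM, with an expected range from 50000 nM to 200000 nM.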

Compound 3, half-maximal inhibitory concentration: > 100000 nM
Compound 3 was reported as a limit; the forecaster's own chance of this, stated with the estimate: 85%; the middle value sits exactly at the limit.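

Compound 3 gives > 100000 nM in this assay, a limit and not a number. No step linking compound 3 to compound 1 or compound 2 can be read, because each value is a limit: the limit of > 100000 nM in this assay, at which 3 of the 3 values shown sit.

The compounds shown leave open how far any of these sulfonamide nitrogen groups differ in this assay.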